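This account rests on a few compounds, and the source may have more. Where it says the series, first, only, none or still open, it means among the compounds named here.

Series notes. In a functional assay on HEK293 cells for agonist activity at Glucose-dependent insulinotropic receptor (Homo sapiens), read by cAMP accumulation, with a stated time of 30 min (a higher number here means that more compound is needed for the effect, a lower number that less compound is needed), compound 2 `CC(C)(OC(=O)N1CCC(n2ncc3cc(-c4ccc(S(C)(=O)=O)cc4)ncc32)CC1)C(F)F` gives 23 nM; compound 1 `CC(C)OC(=O)N1CCC(n2ncc3cc(-c4ccc(S(C)(=O)=O)cc4F)ncc32)CC1` gives 27 nM and compound 3 `CCc1cnc(N2CCC(n3ncc4cc(-c5ccc(S(C)(=O)=O)cc5)ncc43)CC2)nc1` gives 13 nM, so compound 2 holds the second highest of the three numbers, with both gaps inside the scatter. Within the data shown here, the only single-point step on record, a 1.8-fold lower number from compound 2 to compound 3 (0.25 log units; within the scatter), swaps the group on the amine nitrogen in a ring and stays within the scatter. Compound 4 `CC(C)(OC(=O)N1CCC(n2ncc3cc(-c4ccc(S(C)(=O)=O)cc4F)ncc32)CC1)C(F)F` differs from compound 2 by fluoro in place of hydrogen on an aromatic carbon. Among the measured compounds shown here, no measured step isolates this change: compound 1 carries the same fluoro but also a different group on the ring amine, and its number and that of compound 2 lie within the scatter of each other. The expected step of a 1.0-fold lower number from compound 2 to compound 4 (0.02 log units; within the scatter) is therefore none beyond the scatter. Compound 4 is estimated at 22 nM, range 10 nM to 50 nM.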

Compound 4, half-maximal effective concentration: 10 nM
Beside the measured number, compound 4's estimate is 2.2-fold (0.34 log units) above it; measured number inside the range.
By their numbers in this assay, from the lowest: compounds 4, 3, 2 and 1 (each within the scatter of the next, the first and the last beyond it).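

Fluoro in place of hydrogen on an aromatic carbon, ortho to a large group, now gives a step beyond the scatter with the group on the ring amine unchanged: a 2.3-fold lower number from compound 2 to compound 4 (0.36 log units; beyond the scatter). With that fluoro present, difluoromethyl in place of hydrogen on the saturated chain carbon also gives a step beyond the scatter: a 2.7-fold lower number from compound 1 to compound 4 (0.43 log units; beyond the scatter). No supporting data bear on either step.

Going by these compounds, whether the fluoro step carries over with the 5-ethylpyrimidin-2-yl group of compound 3 on the ring amine remains open. So does how chloro or methoxy would compare on the same aromatic carbon.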